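The source may report more compounds than this note shows. Statements on the series, on what has been measured and on what is new or still open speak of the compounds shown alone.

Working notes on the series in an ADME assay on BCBL1 cells (Homo sapiens) for cytotoxicity, with a stated time of 7 days; a higher number here means that more compound is tolerated, a lower number that less compound is tolerated. Compound 3 (`CCCCCCOc1nc(N)nc2c1ncn2/C=C1/CC1(CO)CO`) gives > 20000 nM, which is a limit and not a number. Compound 1 (`COCCOc1nc(N)nc2c1ncn2/C=C1/CC1(CO)CO`) gives > 20000 nM, also a limit. Going by the values given here, compound 2 (`Nc1nc(NCc2ccccc2)c2ncn(/C=C3/CC3(CO)CO)c2n1`) gives 19900 nM, the only readable number of the three. Among the compounds with values here, the series so far stands against (the limit of > 20000 nM in this assay, at which 2 of the 3 values shown sit).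

Compound 4 (`CCCCNc1nc(N)nc2c1ncn2/C=C1/CC1(CO)CO`) has butylamino in place of hexyloxy on an aromatic carbon.

The closest measured change is a number no lower from compound 2 to compound 3 (the limit leaves the size open), which exchanges the same kind of groups at the same place, with benzylamino as the amino partner. The change a number no higher from compound 1 to compound 2 (the limit leaves the size open) runs the same way as the step to compound 4, from an oxygen-linked chain to an amino group. The change a step that the two limits leave unreadable from compound 1 to compound 3 alters only the chain and bears less on this step. None of the three has a readable size, so they set no firm scale. Compound 2 still shows that an amino group at this place can give 19900 nM, so no large drop is foreseen. The expected change is small, and any movement is expected to be downward: an at least 1.0-fold lower number from compound 3 to compound 4 (0.02 log units; that floor lies within the scatter). For compound 4 the estimate is 19000 nM, with an expected range of 9000 nM to 30000 nM, and a further limit is quite possible.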

Compound 4, half-maximal cytotoxic concentration: > 20000 nM
Compound 4 was reported as a limit; the forecaster's own chance of this, stated with the estimate: 55%; middle value at least 1.0-fold (0.02 log units) from the limit.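

In this assay compound 4 gives > 20000 nM, which is a limit and not a number. Butylamino on this aromatic carbon therefore sits at the same limit as hexyloxy and 2-methoxyethoxy, so this position now carries an alkyl chain through either nitrogen or oxygen without a readable value, and replacing the phenyl of the benzylamino group with propyl gives a number no lower from compound 2 to compound 4 (the limit leaves the size open). The steps to compound 4 from compound 1 and compound 3 cannot be read, and the series remains pressed against one ceiling: the limit of > 20000 nM in this assay, at which 3 of the 4 values shown sit.

On these data alone, the size of every step at this position remains open, as does whether any alkylamino or alkoxy chain differs from another in this assay. Groups such as octylamino, dimethylamino or a carboxylic acid on a chain at this aromatic carbon would show whether a readable value can be reached at all.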